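The source may report more compounds than this note shows. Statements on the series, on what has been measured and on what is new or still open speak of the compounds shown alone.

In an ADME assay on Vero cells (Chlorocebus sabaeus) for cytotoxicity, read by MTT assay, with a stated time of 48 h (on this read-out lower numbers stand for stronger inhibition and higher numbers for weaker inhibition), compound 1, `CS(=O)(=O)OC1CCC(CN2CCN(c3cc(=O)c4cc(C(F)(F)F)cc([N+](=O)[O-])c4s3)CC2)CC1`, gives > 64 ug/mL, which is a limit of the assay and not a number. Compound 2, `CCCC(=O)OC1CCC(CN2CCN(c3cc(=O)c4cc(C(F)(F)F)cc([N+](=O)[O-])c4s3)CC2)CC1`, gives > 64 ug/mL, also a limit. Compound 3, `O=C(OC1CCC(CN2CCN(c3cc(=O)c4cc(C(F)(F)F)cc([N+](=O)[O-])c4s3)CC2)CC1)c1cccc(C(F)(F)F)c1`, gives > 64 ug/mL, again a limit. Compound 1 therefore has no exact place in the series, and the whole set sits at the limit of > 64 ug/mL in this assay, at which 3 of the 3 values shown sit.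

Compound 4, `CS(=O)(=O)NC1CCC(CN2CCN(c3cc(=O)c4cc(C(F)(F)F)cc([N+](=O)[O-])c4s3)CC2)CC1`, carries methanesulfonamido in place of (methylsulfonyl)oxy on a saturated ring carbon. The nearest measured changes alter the group on the same oxygen, giving a step that the two limits leave unreadable from compound 1 to compound 2, a step that the two limits leave unreadable from compound 1 to compound 3 and a step that the two limits leave unreadable from compound 2 to compound 3. None of these has a readable size, and none replaces that oxygen with a nitrogen, so they bear on the new change only indirectly. With the limit of > 64 ug/mL in this assay, at which 3 of the 3 values shown sit, no step beyond the scatter is expected in this assay, and no direction can be given. The expected outcome is a step that the limit leaves unreadable from compound 1 to compound 4. Compound 4 is expected at 90 ug/mL, with an estimated range of 40 ug/mL to 128 ug/mL, and will most likely be reported as a limit again.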

Compound 4, half-maximal inhibitory concentration: 48.5 ug/mL
Compound 4: middle estimate off by 1.9-fold (0.27 log units), on the high side; the range from low to high includes it.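

In this assay, going by these compounds alone, compound 4 gives 48.5 ug/mL, the first value that is a number and not a limit, so this saturated ring carbon can carry a group that brings a reading into the measured range. Against the two groups joined through oxygen, the change reads as an at least 1.3-fold lower number from compound 1 to compound 4 (0.12 log units; that floor lies within the scatter) and as an at least 1.3-fold lower number from compound 2 to compound 4 (0.12 log units; that floor lies within the scatter); these are floors, and neither shows by itself a step beyond the scatter. Compound 4 alone leaves the limit at which the compounds joined through oxygen remain: the limit of > 64 ug/mL in this assay, at which 3 of the 4 values shown sit.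

As far as these compounds go, whether a free amine or an acetamide on the same ring carbon would also give a number stays open. Also open, from the compounds shown here alone, is whether the reading follows the nitrogen itself or its pairing with methylsulfonyl.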